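The source may report more compounds than this note shows. Statements on the series, on what has been measured and on what is new or still open speak of the compounds shown alone.

Measured in a functional assay on the whole organism (strain Swiss albino) with Mus musculus as the target, in the maximal electroshock model, with a stated time of 2 h; on this read-out higher numbers stand for an effect only at larger amounts of compound and lower numbers for an effect already at smaller amounts:

compound 1 `Cc1ccccc1N1C(=O)C(c2ccccc2)CC(c2ccccc2)C1=O`: 21.5 mg/kg
compound 2 `Cc1ccc(N2C(=O)C(c3ccccc3)CC(c3ccccc3)C2=O)cc1`: 82 mg/kg
compound 3 `Cc1ccccc1N1C(=O)C(c2ccccc2Cl)CC(c2ccccc2Cl)C1=O`: 27.4 mg/kg

Compound 4 `Cc1ccc(N2C(=O)C(c3ccccc3Cl)CC(c3ccccc3Cl)C2=O)cc1` has not yet been measured in this assay.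

For the measured compounds named here, the only change that occurs twice in this set is the move of the methyl on the aryl group carried by the ring nitrogen. Compound 2 differs from compound 1 by 4-methylphenyl in place of 2-methylphenyl on an amide-type nitrogen in a ring. In this assay this gave a 3.8-fold higher number from compound 1 to compound 2 (0.58 log units; beyond the scatter).

Compound 4 differs from compound 3 by 4-methylphenyl in place of 2-methylphenyl on an amide-type nitrogen in a ring. The surroundings of the place are not identical: in compound 1 and compound 2 the two ring atoms flanking the amide-type nitrogen each bear a phenyl group, while in compound 3 and compound 4 each bears a 2-chlorophenyl group. The change is therefore the same kind of change as that from compound 1 to compound 2, not the same change. How the core of compound 3 differs from the core of compound 1 is not broken down here; the values of compound 1 and compound 3 in this assay lie within the usual scatter of each other.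

Going by the values given here, with a single precedent, the expectation for compound 4 is that the step from compound 3 will be of about the same size as that from compound 1 to compound 2, because a 3.8-fold higher number from compound 1 to compound 2 (0.58 log units; beyond the scatter) is the only measured instance of this kind of change. The expected step is a 3.5-fold higher number from compound 3 to compound 4 (0.54 log units; beyond the scatter). Compound 4 is thus estimated at 95 mg/kg in this assay, with an expected range from 45 mg/kg to 200 mg/kg.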

Compound 4, dose for half-maximal effect: 41.2 mg/kg
Compound 4: the middle estimate sits 2.3-fold (0.36 log units) above what was measured, and the stated range ends above it.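

In this assay, moving the methyl from 2-methylphenyl to 4-methylphenyl on the amide-type nitrogen gives a 1.5-fold higher number from compound 3 to compound 4 (0.18 log units; within the scatter) on the core whose two ring atoms each bear a 2-chlorophenyl group. For the compounds shown here, this does not show that the change behaves differently on the two cores, and neither does it establish a common size for the step: only the step on the phenyl-bearing core lies beyond the scatter, and two pairs of compounds are too few to support a rule for the series. Set side by side, the two steps cannot be told apart on the present numbers: the same change on two cores in this assay, a 3.8-fold higher number (0.58 log units; beyond the scatter) from compound 1 to compound 2 and a 1.5-fold higher number (0.18 log units; within the scatter) from compound 3 to compound 4, 2.5-fold (0.40 log units) apart, within the scatter of two such steps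

The compounds shown leave open whether the step would hold on a core in which the two ring atoms each bear a phenyl group carrying a fluorine or a methoxy group instead of the chlorine, so the dependence of the step on the core remains untested beyond these two cases. They also leave open what the same place on the nitrogen-bound aryl group would tolerate if the methyl gave way to an ethyl group, a longer chain, an amine or a carboxylic acid.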